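A few compounds are considered here, and "the series" means these few. Any claim that something is new, unique, unknown or untested is made for them only; others in the source may bear on it.

The measured compounds in an assay on isolated protein for inhibition of Type-2 angiotensin II receptor (Rattus norvegicus) (a higher number here means a weaker inhibitor, a lower number a stronger inhibitor), are:

Compound 1 `CCCc1nc(CC)c(C(=O)CCN(C(=O)c2ccncc2)c2cccnc2)n1Cc1ccc(-c2ccccc2S(=O)(=O)NC(=O)OCCC(C)C)cc1F` gives 1 nM.
Compound 2 `CCCc1nc(CC)c(C(=O)CCN(C(=O)c2cccnc2)c2cccnc2)n1Cc1ccc(-c2ccccc2S(=O)(=O)NC(=O)OCCC(C)C)cc1F` gives 0.22 nM.
Compound 3 `CCCc1nc(CC)c(C(=O)CCN(C(=O)C(C)C)c2cccnc2)n1Cc1ccc(-c2ccccc2S(=O)(=O)NC(=O)OCCC(C)C)cc1F` gives 1 nM.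

Compound 3 stands level with compound 1 at the digits reported, and the two share the highest numbers of the three in this assay; compound 2 sits apart from them, as the step of a 4.5-fold higher number from compound 2 to compound 3 (0.66 log units; beyond the scatter) shows. All three compounds differ only in the group on a carbonyl carbon, and the two steps that reach compound 3, no change at the digits printed from compound 1 to compound 3 (within the scatter) and a 4.5-fold higher number from compound 2 to compound 3 (0.66 log units; beyond the scatter), show that swapping groups at that carbon moves the number by at most a modest amount.

Compound 4 `CCCc1nc(CC)c(C(=O)CCN(C(C)=O)c2cccnc2)n1Cc1ccc(-c2ccccc2S(=O)(=O)NC(=O)OCCC(C)C)cc1F` carries the change (methyl in place of isopropyl on a carbonyl carbon). Among the measured compounds shown here, no measured step shrinks an alkyl group at that carbon; the closest guide is that replacing a pyridyl ring by isopropyl in the step of no change at the digits printed from compound 1 to compound 3 (within the scatter) left the number unchanged, so the groups at this position appear to be tolerated over a modest span. A small change, most likely none beyond the scatter, is expected in this assay, with a slight lean toward a higher number.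

The estimated step is a 1.5-fold higher number from compound 3 to compound 4 (0.18 log units; within the scatter). Compound 4 is expected to give 1.5 nM, within a range from 0.5 nM to 5 nM.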

Compound 4, half-maximal inhibitory concentration: 3 nM
For compound 4 the middle estimate is 2.0-fold (0.30 log units) below the measured one, and the stated range covers the measured number.
By their numbers in this assay, from the lowest: compound 2; then compounds 1 and 3 (each within the scatter of the next); then compound 4.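

In this assay, among the compounds shown here, the first change between two alkyl groups at this carbonyl carbon, with its other neighbour the amide-type nitrogen, gave a 3.0-fold higher number from compound 3 to compound 4 (0.48 log units; beyond the scatter), showing that alkyl size here can shift the number beyond the scatter even though isopropyl and pyridin-4-yl had stood level. Methyl also separates from that second group, with a 3.0-fold higher number from compound 1 to compound 4 (0.48 log units; beyond the scatter), and the widest gap comes against pyridin-3-yl, with a 14-fold higher number from compound 2 to compound 4 (1.13 log units; beyond the scatter), the only large step among these compounds, so the span at this position is wider than the earlier modest steps suggested. Nothing measured here explains these differences.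

With only methyl and isopropyl as alkyl groups, the compounds leave open whether ethyl or cyclopropyl would fall between them and whether a longer chain such as n-butyl would continue the same trend. They also leave open whether the gap between the two pyridyl groups extends to phenyl or pyridin-2-yl, and whether a carbonyl carbon carrying a dimethylamino group or a methoxy group would sit nearer to methyl or to pyridin-3-yl.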